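A few compounds are considered here, and "the series" means these few. Any claim that something is new, unique, unknown or untested is made for them only; others in the source may bear on it.

Working notes on the series, read in an ADME assay on Vero cells (Chlorocebus sabaeus) for cytotoxicity, read by MTT assay, with a stated time of 48 h; a lower number here means that less compound is tolerated, a higher number that more compound is tolerated. Compound 1 `COc1ccc(C(C)(C)NC(=O)c2ccc([N+](=O)[O-])o2)cc1` gives 82000 nM, and compound 2 `CN(C)c1ccc(C(C)(C)NC(=O)c2ccc([N+](=O)[O-])o2)cc1` gives 79000 nM, with a 1.0-fold lower number from compound 1 to compound 2 (0.02 log units; within the scatter). Compound 3 `CC(C)(NC(=O)c1ccc([N+](=O)[O-])o1)c1ccc(C(F)(F)F)cc1` stands at > 150000 nM, which is a limit of the assay and not a number. Its two steps are an at least 1.8-fold higher number from compound 1 to compound 3 (0.26 log units; that floor lies within the scatter) and an at least 1.8-fold higher number from compound 2 to compound 3 (0.27 log units; that floor lies within the scatter).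

Compound 4 `CC(C)(NC(=O)c1ccc([N+](=O)[O-])o1)c1ccc(Oc2ccc(Cl)cc2)cc1` carries 4-chlorophenoxy in place of trifluoromethyl on an aromatic carbon. The three measured steps all swap a group at this same place, and none of them reaches beyond the scatter. Among the compounds with values here, no measured compound carries a second aromatic ring at this place, so they bear on the new group only loosely. Compound 1, also joined through oxygen, gives the closest reference at 82000 nM. A modest move to a lower number in this assay is therefore expected, to about the level of that reference. The expected change is an at least 2.1-fold lower number from compound 3 to compound 4 (0.33 log units; beyond the scatter). For compound 4 the estimate is 70000 nM, with an expected range of 25000 nM to 150000 nM.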

Compound 4, half-maximal cytotoxic concentration: 67000 nM
Beside the measured number, compound 4's estimate is 1.0-fold (0.02 log units) above it, and the stated range covers the measured number.
By their numbers in this assay, from the lowest: compounds 4, 2 and 1 (each within the scatter of the next). At a limit, above all of these: compound 3.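

In this assay, within the data shown here, the place on the aromatic carbon now carries a second aromatic ring, and the change from trifluoromethyl to 4-chlorophenoxy gives an at least 2.2-fold lower number from compound 3 to compound 4 (0.35 log units; beyond the scatter), the first step that lies beyond the scatter. That step is only a floor, as compound 3 stands at a limit and not at a number: the limit of > 150000 nM in this assay, at which 1 of the 4 values shown sits. Against the other two groups the added ring moves nothing past the scatter, with a 1.2-fold lower number from compound 2 to compound 4 (0.07 log units; within the scatter) and a 1.2-fold lower number from compound 1 to compound 4 (0.09 log units; within the scatter), so this place accepts 4-chlorophenoxy with a reading level with those of the smaller dimethylamino and methoxy groups.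

Open, from the compounds shown here alone, is how an amine or a carboxylic acid at this place would read, and whether phenoxy without the chlorine would read the same. Also open, going by these compounds, is how far compound 3 lies past its limit, so the full size of its step cannot be told.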